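The source may report more compounds than this note shows. Statements on the series, on what has been measured and on what is new or still open speak of the compounds shown alone.

Of the compounds shown here, three built on one shared core have been measured in a functional assay on HeLa cells for agonist activity at 5-hydroxytryptamine receptor 6 (Homo sapiens), read by cAMP accumulation and immunoassay; a lower number here means a smaller maximal response, a higher number a larger maximal response. Compound 1 `O=S(=O)(c1ccc(F)cc1)c1cn(C2CCNC2)c2ncccc12` gives 50% in this assay. Compound 2 `O=S(=O)(c1ccccc1)c1cn(C2CCCNC2)c2ncccc12` gives 56%. Compound 3 `O=S(=O)(c1ccccc1Cl)c1cn(C2CCCNC2)c2ncccc12` gives 84%, the highest of the three numbers, with compound 2 as its nearest neighbour and compound 1 furthest below it, both gaps lying beyond the scatter. Within the data shown here, the single one-place step among the measured compounds is a number 28 percentage points higher from compound 2 to compound 3 (beyond the scatter).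

Compound 4 `O=S(=O)(c1cccc(Br)c1)c1cn(C2CCCNC2)c2ncccc12` differs from compound 3 in one place: 3-bromophenyl in place of 2-chlorophenyl on a sulfonyl sulfur. The group on the sulfonyl sulfur still carries one halogen, but it is now 3-bromophenyl rather than 2-chlorophenyl. Among the measured compounds shown here, the only step that bears on this is a number 28 percentage points higher from compound 2 to compound 3 (beyond the scatter), which shows that adding chloro to the unsubstituted phenyl raised the maximal response by a modest amount. Nothing measured shows what exchanging chlorine for bromine, or exchanging one halogenated phenyl for another, does on its own, so the account cannot assume the full gain of compound 3 is kept. The expected step is a number 14 percentage points lower from compound 3 to compound 4 (beyond the scatter), a modest decline that could yet fall within the scatter. Compound 4 is therefore expected to give 70%, within a range from 52% to 88%.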

Compound 4, largest response reached (Emax), in percent of the reference or control that the assay uses: 49%
Estimate against measurement, compound 4: 21 percentage points above; measured number outside the range, below it.
By their numbers in this assay, from the lowest: compounds 4, 1 and 2 (each within the scatter of the next); then compound 3.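

In this assay, the step of a number 35 percentage points lower from compound 3 to compound 4 (beyond the scatter) shows that the gain seen with 2-chlorophenyl on the sulfonyl sulfur does not carry over to every halogenated phenyl at this place. The step of a number 7 percentage points lower from compound 2 to compound 4 (within the scatter) adds that 3-bromophenyl is not separated from the unsubstituted phenyl, so carrying a halogen on this ring does not by itself give the higher maximal response of compound 3. Nothing available explains why these two halogenated phenyls part so widely.

Because the step from compound 3 to compound 4 exchanges both the halogen and its place on the ring, the compounds shown leave open which of the two accounts for the loss; a phenyl with bromine where 2-chlorophenyl has its chlorine, or with chlorine where 3-bromophenyl has its bromine, would separate them. Also open, on these data alone, is whether the gain belongs to halogens at all, or whether a methyl, a methoxy or a nitrile on the phenyl would change the maximal response in the same way.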